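Aryl swap on the shared core, single-concentration inhibition

The source may report more compounds than this note shows. Statements on the series, on what has been measured and on what is new or still open speak of the compounds shown alone.

Compound 1 `COc1cc(NC(=O)Nc2cc(Nc3cccc(C(C)(C)C)c3)ncn2)cc(OC)c1` is the lower of the two measured entries: in a functional assay on NCI-H1581 cells (Homo sapiens) for inhibition, read by MTT assay, with a stated time of 48 h, tested at 10 uM (on this read-out higher numbers stand for more inhibition at the one concentration tested (going by the name of the read-out) and lower numbers for less inhibition), compound 1 gives 35.1%, while compound 2 `CC(C)(C)c1ccc(Nc2cc(NC(=O)Nc3c(Cl)cccc3Cl)ncn2)cc1` gives 71.3%, a gap beyond the usual scatter. Compound 3 `COc1cc(NC(=O)Nc2cc(Nc3ccc(Br)cc3OC)ncn2)cc(OC)c1` differs from compound 1 by 4-bromo-2-methoxyphenyl in place of 3-(tert-butyl)phenyl on a nitrogen on an aromatic ring. Among the measured compounds shown here, no measured pair isolates this change, so its effect on the read-out is unknown. For compound 3 the expected step is a number 0.1 percentage points lower from compound 1 to compound 3 (within the scatter), with no clear direction beyond the scatter. The estimate for compound 3 is 35%, with a range from 10% to 65%.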

Compound 3, a percentage reported as inhibition, at one concentration (the size of the read-out at that concentration, not a potency): 20.1%
Compound 3: the middle estimate sits 14.9 percentage points above what was measured; low and high end bracket the measured number.
By their numbers in this assay, from the lowest: compound 3; then compound 1; then compound 2.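

Among the compounds shown here, on a nitrogen on an aromatic ring, 4-bromo-2-methoxyphenyl in place of 3-(tert-butyl)phenyl gives a number 15 percentage points lower from compound 1 to compound 3 (beyond the scatter) in this assay and is the first one-place comparison. This position is therefore not indifferent to the aryl group it carries, at least for these two groups. Nothing at hand explains the step.

As far as these compounds go, the entering group brings bromine and methoxy together, so the share of each in the step stays open. From the compounds shown here alone, how an aryl group carrying a carboxylic acid or a dimethylamino group would read at this place also stays open.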